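Working notes: from alkyl to aryl on nitrogen

The compounds below may be only part of what the source reports. "The series", "measured", "known", "first", "only" and "open" are said of these compounds alone.

compound 1 `COc1cc(-c2nccn2C)cc(OC)c1OC` gives > 100000 nM here
compound 2 `COc1cc(-c2nccn2CC(C)C)cc(OC)c1OC` gives > 100000 nM here
compound 3 `CCCCCn1ccnc1-c1cc(OC)c(OC)c(OC)c1` gives > 100000 nM here

In a functional assay on HeLa cells (Homo sapiens) for antiproliferative activity, read by MTT assay, with a stated time of 72 h (on this read-out higher numbers stand for weaker inhibition and lower numbers for stronger inhibition), compound 1 gives > 100000 nM as a limit, not a number. Compound 1 stands at the limit of > 100000 nM in this assay, at which 3 of the 3 values shown sit, and so holds no rank in the series. Among the compounds with values here, compound 4 `COc1cc(-c2nccn2-c2ccc(C)cc2)cc(OC)c1OC` has 4-methylphenyl in place of methyl on an aromatic nitrogen as its one change. The nearest evidence is a step that the two limits leave unreadable from compound 1 to compound 2 and a step that the two limits leave unreadable from compound 1 to compound 3 on the chain, so no measured size carries over. Only a move toward stronger inhibition could give a number in this assay and so that direction is expected, with another limit quite possible. The expected result is an at least 10-fold lower number from compound 1 to compound 4 (1.00 log units; beyond the scatter) as an estimate only. For compound 4 the estimated value is 10000 nM within an expected range from 300 nM to 100000 nM for now.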

Compound 4, half-maximal inhibitory concentration: 700 nM
Compound 4: middle estimate off by 14-fold (1.15 log units), on the high side, within the range that was stated.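

Placing 4-methylphenyl on the aromatic nitrogen gives the first readable number of the series, with an at least 140-fold lower number from compound 1 to compound 4 (2.15 log units; beyond the scatter) and an at least 140-fold lower number from compound 2 to compound 4 (2.15 log units; beyond the scatter) and an at least 140-fold lower number from compound 3 to compound 4 (2.15 log units; beyond the scatter) on this one change. Methyl, isobutyl and pentyl at this position give no number, so an aromatic ring here separates compound 4 from all three chains. These step sizes are lower bounds because compounds 1, 2 and 3 rest on a limit: the limit of > 100000 nM in this assay, at which 3 of the 4 values shown sit. The compounds shown leave open whether the ring alone or its methyl group carries the step. Phenyl, 4-chlorophenyl or benzyl on this nitrogen would separate these.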